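A few compounds are considered here, and "the series" means these few. Any claim that something is new, unique, unknown or untested is made for them only; others in the source may bear on it.

In a functional assay on ECa-109 cells (Homo sapiens) for cytotoxicity, read by MTT assay, with a stated time of 72 h (on this read-out higher numbers stand for weaker inhibition and lower numbers for stronger inhibition), compound 3 `COc1ccccc1C=C1C(=O)N(c2ccc(Cl)cc2)N(c2ccc(Cl)cc2)C1=O` gives 30400 nM and compound 1 `COc1cccc(C=C2C(=O)N(c3ccc(Cl)cc3)N(c3ccc(Cl)cc3)C2=O)c1O` gives 39000 nM, so these two sit together. Compound 2 `COc1ccc(C=C2C(=O)N(c3ccc(Cl)cc3)N(c3ccc(Cl)cc3)C2=O)cc1` reports only a limit, > 128000 nM. Compound 4 `O=C1C(=Cc2ccco2)C(=O)N(c2ccc(Cl)cc2)N1c1ccc(Cl)cc1` changes the same place as all three measured steps: furan-2-yl in place of 2-methoxyphenyl on a double-bonded chain carbon bound to a double-bonded ring carbon, with furan-2-yl in place of 2-methoxyphenyl on a double-bonded chain carbon bound to a double-bonded ring carbon. Those steps were mixed, namely a 1.3-fold lower number from compound 1 to compound 3 (0.11 log units; within the scatter), an at least 3.2-fold higher number from compound 1 to compound 2 (0.51 log units; beyond the scatter) and an at least 4.2-fold lower number from compound 2 to compound 3 (0.62 log units; beyond the scatter). A swap here can therefore do little or a good deal, and compound 3 offers the closest starting point. The estimated change is a 1.6-fold higher number from compound 3 to compound 4 (0.22 log units; within the scatter), a small expected drift toward weaker inhibition. Compound 4 is expected at 50000 nM, within an estimated range of 17000 nM to 128000 nM.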

Compound 4, half-maximal inhibitory concentration: 14300 nM
Compound 4: the middle estimate sits 3.5-fold (0.54 log units) above what was measured; measured number outside the range, below it.
By their numbers in this assay, from the lowest: compound 4; then compounds 3 and 1 (each within the scatter of the next). At a limit, above all of these: compound 2.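

At this place, furan-2-yl gives a lower number than either methoxy-bearing ring that stands within the scatter of it: a 2.1-fold lower number from compound 3 to compound 4 (0.33 log units; beyond the scatter) and a 2.7-fold lower number from compound 1 to compound 4 (0.44 log units; beyond the scatter), which makes compound 4 the lowest of the set and shows that no methoxy group is required here. The step against the third ring is an at least 8.9-fold lower number from compound 2 to compound 4 (0.95 log units; beyond the scatter). Compound 2 reports only a limit, so that step is a bound: the limit of > 128000 nM in this assay, at which 1 of the 4 values shown sits.

A single furan cannot separate the effect of ring size from the loss of the methoxy group. As far as these compounds go, whether thiophen-2-yl, plain phenyl or a furan carrying an amine would do the same remains open.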